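The source may hold more compounds than are shown below. What is called first, only, known or untested is meant among the compounds shown, and "the series" means these compounds.

The series was examined in an ADME assay on HCT-116 cells (Homo sapiens) for cytotoxicity, read by CellTiter-Glo, with a stated time of 72 h (on this read-out lower numbers stand for stronger inhibition and higher numbers for weaker inhibition), and none of the three measured compounds gave a number there. Compound 1 `Cc1ccc(S(=O)(=O)N2CCC(N3CCC(C)CC3)CC2)cc1C` gives > 5000 nM, which is a limit of the assay rather than a measured value. Compound 2 `Cc1cc(C)c(S(=O)(=O)N2CCC(N3CCC(CCC#N)CC3)CC2)c(C)c1` gives > 5000 nM, also a limit. Compound 3 `Cc1cc(C)c(S(=O)(=O)c2ccc(N3CCC(C)CC3)cc2)c(C)c1` gives > 5000 nM, again a limit. Taken together, (the limit of > 5000 nM in this assay, at which 3 of the 3 values shown sit), so compound 1 stands where every other compound in this set stands, at the limit, and no ordering among them can be read from these data.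

Compound 4 `CCc1ccc(S(=O)(=O)N2CCC(N3CCC(C)CC3)CC2)cc1` differs from compound 1 by a single change, (4-ethylphenyl in place of 3,4-dimethylphenyl on a sulfonyl sulfur). For the measured compounds named here, no step between two measured compounds is available to calibrate the effect of such a rearrangement. With all three measured values sitting at the limit, no change beyond the usual scatter is expected for this step, and the estimate means a step that the limit leaves unreadable from compound 1 to compound 4. Compound 4 is therefore expected to give roughly 8000 nM in this assay, with a range from 4000 nM to 20000 nM, most likely reported again only as a limit.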

Compound 4, half-maximal inhibitory concentration: > 5000 nM
Compound 4: no number, only a limit; the forecaster's own chance of this, stated with the estimate: 85%; the middle value lies beyond the limit too.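

No step can be read between compound 1 and compound 4, as each gives only a limit and not a number: the limit of > 5000 nM in this assay, at which 4 of the 4 values shown sit.

The compounds shown leave open how far each lies past that limit, and so whether they differ at all in this assay.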